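Azido for hydroxy on compound 3

This account rests on a few compounds, and the source may have more. Where it says the series, first, only, none or still open, it means among the compounds named here.

In an ADME assay on L1210/0 cells (Mus musculus) for cytotoxicity, with a stated time of 48 h (on this read-out lower numbers stand for stronger inhibition and higher numbers for weaker inhibition), compound 1 `O[C@H]1C[C@@H](Cn2cnc3c(-c4ccccc4)ncnc32)c2ccccc21` gives > 200000 nM as a limit of the assay. Compound 2 `Nc1ncnc2c1nnn2C1C[C@H](CO)[C@@H](CO)[C@@H]1CO` gives > 200000 nM as a limit too. Among the compounds with values here, compound 3 `O=c1[nH]c(=O)n([C@H]2C[C@H](O)[C@@H](CO)O2)cc1CO` gives 9180 nM as the only true number of the three. Compound 4 `[N-]=[N+]=NCc1cn([C@H]2C[C@H](O)[C@@H](CO)O2)c(=O)[nH]c1=O` departs from it by one change azido in place of hydroxy on a saturated chain carbon bound to an aromatic carbon with azido in place of hydroxy on a saturated chain carbon bound to an aromatic carbon. Within the data shown here, no measured pair shows what this change does, so only a small shift is expected in this assay and none beyond the scatter. The expected step of a 1.5-fold higher number from compound 3 to compound 4 (0.18 log units; within the scatter) leans slightly towards weaker inhibition. Compound 4 is estimated at 14000 nM with an expected range from 3500 nM to 60000 nM in this reading.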

Compound 4, half-maximal inhibitory concentration: 124000 nM
Estimate against measurement, compound 4: 8.9-fold (0.95 log units) below; measured number outside the range, above it.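

In this assay azidomethyl in place of hydroxymethyl brings a 14-fold higher number from compound 3 to compound 4 (1.13 log units; beyond the scatter) at this place, on a saturated chain carbon bound to an aromatic carbon. This first measured step shows that the change is far from neutral at this position, with inhibition clearly weaker. Compound 4 still gives a true number, though the read-out has a ceiling: the limit of > 200000 nM in this assay, at which 2 of the 4 values shown sit. A single replacement cannot tell whether losing the hydroxy or bringing in the azido accounts for the step. As far as these compounds go, how an amine or a methyl ether would read at this place stays open.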